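Trading Trifluoromethyl for Fluoro on the Shared Core

The compounds below may be only part of what the source reports. "The series", "measured", "known", "first", "only" and "open" are said of these compounds alone.

The three measured compounds share one core and differ only in the groups carried on their two outer rings. In a functional assay on A549 cells (Homo sapiens) for cytotoxicity, read by MTT assay, with a stated time of 48 h (on this read-out lower numbers stand for stronger inhibition and higher numbers for weaker inhibition), compound 1 `O=C(/C=C\Nc1ccc(F)cc1)c1nc(-c2ccc(F)cc2)n2ccccc12` gives 13200 nM. Compound 2 `COc1ccc(N/C=C\C(=O)c2nc(-c3ccc(F)cc3)n3ccccc23)cc1` gives 19200 nM, and compound 3 `O=C(/C=C\Nc1ccc(Cl)cc1)c1nc(-c2ccc(C(F)(F)F)cc2)n2ccccc12` gives 18500 nM. Compound 3 thus stands second highest of the three numbers, nearest to compound 2 and furthest from compound 1, with both gaps within the scatter. For the measured compounds named here, the one step between measured compounds that differ in a single place, a 1.5-fold higher number from compound 1 to compound 2 (0.16 log units; within the scatter), moved the number no further than the scatter allows.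

Compound 4 `O=C(/C=C\Nc1ccc(Cl)cc1)c1nc(-c2ccc(F)cc2)n2ccccc12` differs from compound 3 by fluoro in place of trifluoromethyl on an aromatic carbon. Going by the values given here, no measured step touches the group on this ring, so the nearest guide is compound 1, whose structure differs from that of compound 4 by a single group on the other outer ring; in this assay compound 1 gives 13200 nM. The expected step is a 1.3-fold lower number from compound 3 to compound 4 (0.11 log units; within the scatter), nothing beyond the scatter. Compound 4 is therefore estimated to give 14500 nM, with a range from 7000 nM to 30000 nM.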

Compound 4, half-maximal inhibitory concentration: 5090 nM
The estimate for compound 4 lay 2.8-fold (0.45 log units) above the measured number; measured number outside the range, below it.
By their numbers in this assay, from the lowest: compound 4; then compounds 1, 3 and 2 (each within the scatter of the next).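

Exchanging trifluoromethyl for fluoro on an aromatic carbon, para to a large group, brings a 3.6-fold lower number from compound 3 to compound 4 (0.56 log units; beyond the scatter) in this assay, so the group at this place does move the number when chloro sits on the other outer ring. That other ring had shown no change beyond the scatter in the only earlier step, yet with the fluoro group held fixed, chloro in place of methoxy brings a 3.8-fold lower number from compound 2 to compound 4 (0.58 log units; beyond the scatter) and chloro in place of fluoro brings a 2.6-fold lower number from compound 1 to compound 4 (0.41 log units; beyond the scatter), leaving compound 4 with the lowest number of the four. Nothing available here accounts for these steps.

Compound 3 is the only compound shown with trifluoromethyl, so it remains open whether the same exchange would count for as much with fluoro or methoxy on the other ring. Also open, as far as these compounds go, is how bromo, an amine or a carboxylic acid would compare with chloro, or a longer chain with fluoro.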